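Notes on the ring-nitrogen substituent in the series

A few compounds are considered here, and "the series" means these few. Any claim that something is new, unique, unknown or untested is made for them only; others in the source may bear on it.

Three measured compounds share a core and differ in the ring fused to the aryl ether and in the group on its ring nitrogen. Compound 1 `O=C(O)c1cc(-c2cccc(COc3ccc4c(=O)n(C5CCCC5)oc4c3)c2)ccc1Cl` gives 310 nM in an assay on HEK293 cells for positive allosteric modulation of metabotropic glutamate receptor 2 (Rattus norvegicus), read by thallium flux; a lower number here means that less compound is needed, a higher number that more compound is needed for the effect. Compound 2 `O=C(O)c1cc(-c2cccc(COc3ccc4c(c3)CN(Cc3ccc(C(F)(F)F)cc3)C4=O)c2)ccc1Cl` gives 350 nM in this assay, the highest of the three numbers, though its gaps to compound 1 and to compound 3 both lie within the scatter. Compound 3 `O=C(O)c1cc(-c2cccc(COc3ccc4c(c3)CCN(C3CCCC3)C4=O)c2)ccc1Cl` gives 300 nM in this assay.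

Compound 4 `O=C(O)c1cc(-c2cccc(COc3ccc4c(c3)CN(C3CC3)C4=O)c2)ccc1Cl` is not yet measured. It differs from compound 2 by cyclopropyl in place of 4-(trifluoromethyl)benzyl on an amide-type nitrogen in a ring. For the measured compounds named here, no step between measured compounds isolates this change; compound 1 and compound 3 carry a cyclopentyl on the ring nitrogen and give numbers close to that of compound 2, so the three numbers lie close together. For compound 4 no step beyond the scatter is expected, and the step of a 1.1-fold higher number from compound 2 to compound 4 (0.06 log units; within the scatter) is expected to be small, in either direction. Compound 4 is estimated at 400 nM in this assay, with a range from 150 nM to 1200 nM.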

Compound 4, half-maximal effective concentration: 220 nM
Compound 4: middle estimate off by 1.8-fold (0.26 log units), on the high side; the measured number falls inside the stated range.
By their numbers in this assay, from the lowest: compounds 4, 3, 1 and 2 (each within the scatter of the next).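

Cyclopropyl in place of 4-(trifluoromethyl)benzyl on the amide-type nitrogen gives the first step in the series that isolates the group at this position: in this assay it is a 1.6-fold lower number from compound 2 to compound 4 (0.20 log units; within the scatter). The number therefore stays within the scatter whether this nitrogen carries a group of 11 heavy atoms with a six-membered aromatic ring or one of 3 heavy atoms with a three-membered ring, so on this single pair the aromatic ring is not needed to hold the number in this range. Nothing available bears on why the number holds across this change.

Still open, as far as these compounds go, is whether the amide hydrogen alone, a methyl group or a longer chain on this nitrogen would keep the number in this range. The same applies to an amine or a carboxylic acid carried on the group at this position.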